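A few compounds are considered here, and "the series" means these few. Any claim that something is new, unique, unknown or untested is made for them only; others in the source may bear on it.

Measured so far:
- compound 1 `CCCCCC[C@@H](O)C/C=C\CCCCCCCC(=O)N[C@@H](C)c1ccccc1` gives 11.1 ug/mL
- compound 2 `CCCCCCCCCCCCCCCCCC(=O)N1CCOCC1` gives 43.3 ug/mL
- compound 3 `CCCCC/C=C\C/C=C\CCCCCCCC(=O)N1CCCCC1` gives 48.9 ug/mL

These three numbers come from a functional assay on OVCAR-3 cells (Homo sapiens) for antiproliferative activity, read by sulforhodamine B assay, with a stated time of 48 h; on this read-out lower numbers stand for stronger inhibition of growth and higher numbers for weaker inhibition of growth. Compound 2 stands second highest of the three; its nearest neighbour is compound 3, within the scatter, and its furthest is compound 1, which lies beyond the scatter with a lower number. Compound 4 `CCCCCCCCCCCCCCCCCC(=O)N1CCCC1` is not yet measured. The difference from compound 2 is pyrrolidin-1-yl in place of morpholin-4-yl on a carbonyl carbon. Within the data shown here, no measured pair shows this change, so its effect is unknown. Compound 2 and compound 3 carry different saturated rings on the carbonyl yet give numbers within the scatter of each other, which suggests no step beyond the scatter in this assay . Compound 4 is therefore expected near compound 2, at 38 ug/mL, within 15 ug/mL to 100 ug/mL, the expected step being a 1.1-fold lower number from compound 2 to compound 4 (0.06 log units; within the scatter).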

Compound 4, concentration for 50% growth inhibition: 7.3 ug/mL
Estimate against measurement, compound 4: 5.2-fold (0.72 log units) above; measured number outside the range, below it.
By their numbers in this assay, from the lowest: compounds 4 and 1 (each within the scatter of the next); then compounds 2 and 3 (each within the scatter of the next).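

In this assay, among these compounds, the first measured pair at this position shows that the group on the carbonyl carbon matters: pyrrolidin-1-yl in place of morpholin-4-yl gives a 5.9-fold lower number from compound 2 to compound 4 (0.77 log units; beyond the scatter), a step beyond the scatter. The change swaps a six-membered ring with two hetero atoms for a five-membered ring with one, so ring size and the ring oxygen change together. Nothing available explains this step.

Which of those two differences counts remains open, as does whether an azetidin-1-yl ring or an open-chain diethylamino group on the same carbonyl would match compound 4.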